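The compounds below may be only part of what the source reports. "The series", "measured", "known", "first", "only" and "open" are said of these compounds alone.

Compound 1 `C[n+]1ccn(CCOCCF)c1/C=N/O` gives -2.62 in a physicochemical assay for lipophilicity; a higher number here means a more lipophilic compound, a lower number a more polar compound.
Compound 2 `C[n+]1ccn(CCOCCCl)c1/C=N/O` gives -2.32.
Compound 3 `C[n+]1ccn(COCCCBr)c1/C=N/O` gives -1.76.

Among these three numbers compound 2 stands second highest; the nearest step is a number 0.30 log units higher from compound 1 to compound 2 (within the scatter) and the furthest is a number 0.56 log units higher from compound 2 to compound 3 (beyond the scatter). Compound 4 `C[n+]1ccn(CCN2CCCC2)c1/C=N/O` differs from compound 2 by pyrrolidin-1-yl in place of 2-chloroethoxy on a saturated chain carbon, two bonds along the chain from an aromatic nitrogen. Among the measured compounds shown here, no measured step involves a pyrrolidin-1-yl: the steps of a number 0.30 log units higher from compound 1 to compound 2 (within the scatter) and a number 0.86 log units higher from compound 1 to compound 3 (beyond the scatter) concern halogen and chain exchanges on the same arm, so they fix the scale of the numbers in this assay but do not bear directly on this change. The account therefore expects compound 4 to fall at -3.1, between -3.9 and -2.3. That is an expected step of a number 0.78 log units lower from compound 2 to compound 4 (beyond the scatter).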

Compound 4, distribution coefficient: -2.73
Estimate against measurement, compound 4: 0.37 log units below; measured number inside the range.
By their numbers in this assay, from the lowest: compounds 4, 1 and 2 (each within the scatter of the next, the first and the last beyond it); then compound 3.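

Placing pyrrolidin-1-yl on a saturated chain carbon, two bonds along the chain from an aromatic nitrogen, gives a number 0.41 log units lower from compound 2 to compound 4 (beyond the scatter) when it replaces 2-chloroethoxy. When it replaces 2-fluoroethoxy, the same placement gives a number 0.11 log units lower from compound 1 to compound 4 (within the scatter) in this assay, so the ring-bearing arm separates from the chloro arm but not from the fluoro arm. Nothing available here explains these steps. From the compounds shown here alone, it remains open whether a morpholine ring, an open-chain diethylamine or a longer chain carrying pyrrolidin-1-yl would give a similar number.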